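A few compounds are considered here, and "the series" means these few. Any claim that something is new, unique, unknown or untested is made for them only; others in the source may bear on it.

Compound 1 `CCC(COc1cccc(C(F)(F)F)c1)OC(=O)NCCCc1ccccc1` — in an assay for inhibition of zeta-carotene desaturase, chloroplastic/chromoplastic (Capsicum annuum), using a Dixon plot, with a stated time of 8 h (on this read-out lower numbers stand for stronger inhibition and higher numbers for weaker inhibition), compound 1 gives > 100000 nM, a limit of the assay, not a number.
Compound 2 `CCC(COc1cccc(C(F)(F)F)c1)OC(=O)NCc1cccc(Cl)c1` — in this assay compound 2 gives > 100000 nM, likewise a limit.

The step that the two limits leave unreadable from compound 1 to compound 2 cannot be read since both values sit at the limit of > 100000 nM in this assay, at which 2 of the 2 values shown sit. Compound 2 therefore stands at that limit and nowhere more precise. Compound 3 `CCC(COc1cccc(C(F)(F)F)c1)OC(=O)NCc1ccc(Cl)cc1` differs from compound 2 by 4-chlorophenyl in place of 3-chlorophenyl on a saturated chain carbon bound to an amide-type nitrogen. Going by the values given here, the only measured step is a pair of limits and gives no size, so no change beyond the scatter is expected; the expected step is a step that the limit leaves unreadable from compound 2 to compound 3. Compound 3 is estimated at 150000 nM, range 50000 nM to 500000 nM, most likely reported again only as a limit.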

Compound 3, half-maximal inhibitory concentration: > 100000 nM
Compound 3 gave a limit, no number; the forecaster's own chance of this, stated with the estimate: 80%; the middle value does not contradict the limit.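

No step can be read among compound 1, compound 2 and compound 3, since all three give only a limit: the limit of > 100000 nM in this assay, at which 3 of the 3 values shown sit. The compounds shown leave open whether any change at this place on the shared core brings a value inside the range of this assay.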